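Swapping a Methoxyphenoxy Arm for Benzyl

The source may hold more compounds than are shown below. What is called first, only, known or untested is meant among the compounds shown, and "the series" means these compounds.

Compound 1 `COc1ccc(Oc2ccc3cc(NC(=O)c4ccc(OC)c(-c5cccc(OC)c5)c4)c(=O)oc3c2C)cc1` was tested in a functional assay on MCF7 cells (Homo sapiens) for antiproliferative activity; on this read-out higher numbers stand for weaker inhibition and lower numbers for stronger inhibition. In this assay compound 1 gives > 100000 nM, which is a limit of the assay rather than a number, so compound 1 stands at the edge of what the assay can report. Compound 2 `COc1ccc(Nc2ccc3cc(NC(=O)c4ccc(OC(C)=O)c(CC=C(C)C)c4)c(=O)oc3c2C)cc1` likewise gives only a limit, > 100000 nM in this assay. For the measured compounds named here, compound 3 `COc1cc(Cc2ccc3cc(NC(=O)c4ccc(O)c(CC=C(C)C)c4)c(=O)oc3c2C)ccc1O` gives 14600 nM in this assay, the only measured number among the three. Two of the three results therefore share (the limit of > 100000 nM in this assay, at which 2 of the 3 values shown sit). Going by the values given here, no pair of measured compounds differs in a single place, so no measured step is available to lean on.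

Compound 4 `COc1cccc(-c2cc(C(=O)Nc3cc4ccc(Cc5ccccc5)c(C)c4oc3=O)ccc2OC)c1` has not yet been measured. It differs from compound 1 by benzyl in place of 4-methoxyphenoxy on an aromatic carbon. Among the compounds with values here, because compound 1 is known only as a limit, the size of the step has no firm anchor, and compound 3 supplies the only number in view. The expected step is an at least 2.5-fold lower number from compound 1 to compound 4 (0.39 log units; beyond the scatter), toward stronger inhibition, with wide uncertainty in both directions. Compound 4 is estimated to give about 40000 nM in this assay, within a range from 8000 nM to 200000 nM, with a real chance that only a limit is reported once more.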

Compound 4, half-maximal inhibitory concentration: 7110 nM
Compound 4: middle estimate off by 5.6-fold (0.75 log units), on the high side, outside the stated range (below it).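

In this assay, benzyl in place of 4-methoxyphenoxy on this aromatic carbon, ortho to a methyl group, gives an at least 14-fold lower number from compound 1 to compound 4 (1.14 log units; beyond the scatter), so this single position can carry a large change in the read-out while the rest of the molecule stays the same. Both groups hold one six-membered aromatic ring of carbon only, so the presence of such a ring at this position does not by itself decide the result. The step has a firm bound but no exact size, since compound 1 is known only as a limit and not as a number: the limit of > 100000 nM in this assay, at which 2 of the 4 values shown sit.

The compounds shown leave open whether the difference follows the atom that links the ring to the core or the methoxy group on that ring; a plain phenoxy group and a 4-methoxybenzyl group at the same carbon would tell these two apart. They also leave open how a simple amine or a carboxylic acid at this carbon would read, as this single pair says nothing about groups without an aromatic ring.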